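The source may hold more compounds than are shown below. What is called first, only, known or untested is meant among the compounds shown, and "the series" means these compounds.

The compounds share one core and are read in a functional assay on L1210 cells (Mus musculus) for inhibition; a lower number here means a stronger inhibitor, a higher number a weaker inhibitor. Compound 1 `C#CCN(Cc1ccc2nc(C)nc(O)c2c1)c1cccc(C#C)c1` gives > 2400 nM, which is a limit and not a number. Compound 2 `C#CCN(Cc1ccc2nc(C)nc(O)c2c1)c1ccc(C#N)cc1` gives > 5000 nM, which is also only a limit. Compound 2 therefore has no numerical position of its own in this assay, and no number is yet available anywhere in the series. Going by the values given here, the one measured change is a step that the two limits leave unreadable from compound 1 to compound 2, and it has no readable size.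

Compound 3 `C#CCN(Cc1ccc2nc(C)nc(O)c2c1)c1ccc(C#N)c(Cl)c1` differs from compound 2 by chloro in place of hydrogen on an aromatic carbon, ortho to a cyano group. Among the compounds with values here, no measured step covers this kind of change, so neither a size nor a direction carries over from the pair in hand. Within the data shown here, the only anchor is compound 2, at the limit of > 5000 nM in this assay, at which 1 of the 2 values shown sits. A step beyond the scatter is not expected, and a further limit is a real possibility. The expected change is a step that the limit leaves unreadable from compound 2 to compound 3. Compound 3 is estimated at 6000 nM, with an expected range of 1500 nM to 25000 nM.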

Compound 3, half-maximal inhibitory concentration: 4500 nM
Estimate against measurement, compound 3: 1.3-fold (0.12 log units) above, and the stated range covers the measured number.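

In this assay, going by these compounds alone, compound 3 gives 4500 nM, the first value that is a number and not a limit, so this chloro-bearing compound, with chloro ortho to a cyano group, gives the series a numerical anchor. The change of hydrogen to chloro at this aromatic carbon reads as an at least 1.1-fold lower number from compound 2 to compound 3 (0.04 log units; that floor lies within the scatter); this establishes no effect beyond the scatter, although the real step could be larger. Only a floor can be stated because compound 2 has a limit and not a number: the limit of > 5000 nM in this assay, at which 1 of the 3 values shown sits.

The earlier step between compound 1 and compound 2 still cannot be read, so the series gives no measured comparison of the 3-ethynylphenyl and 4-cyanophenyl groups on the amine nitrogen. Also open, going by these compounds, is whether fluoro, bromo, methoxy or an amine on the same aromatic carbon would give a step beyond the scatter, and whether chloro would give a readable step on a ring carrying ethynyl in place of cyano.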